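Replacing methoxy with hydrogen on compound 1

The compounds below may be only part of what the source reports. "The series", "measured", "known", "first", "only" and "open" are said of these compounds alone.

Measured values for a physicochemical assay for lipophilicity, measured as octanol-water partition (on this read-out lower numbers stand for lower lipophilicity and higher numbers for higher lipophilicity), follow
compound 1 (`COc1cccc(C(=O)O[C@@H]2C[C@H](C)CC[C@H]2C(C)C)c1`) reads 4.57
compound 2 (`CC(C)[C@@H]1CC[C@@H](C)C[C@H]1OC(=O)/C=C/c1cccc([N+](=O)[O-])c1`) reads 5.18
compound 3 (`CC(C)[C@@H]1CC[C@@H](C)C[C@H]1OC(=O)/C=C/c1ccccc1[N+](=O)[O-]`) reads 5.18

Compound 1 stands lowest of the three numbers, and its gap to compound 2 and to compound 3 lies beyond the scatter. Those two compounds show the same value.

Among the measured compounds shown here, the next compound for this assay is compound 4 (`CC(C)[C@@H]1CC[C@@H](C)C[C@H]1OC(=O)c1ccccc1`), which has no measurement yet. It differs from compound 1 by hydrogen in place of methoxy on an aromatic carbon, and the rest of the structure stays the same.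

For the measured compounds named here, no pair of measured compounds differs in one place only, so the series gives no direct size for this exchange. Compound 2 and compound 3 differ from compound 1 in more than one place, and their gap cannot be assigned to any single change. The natural anchor is therefore compound 1 at 4.57 in the absence of a closer reference. No step beyond the scatter is expected, and no firm direction is expected either. The expected change is a number 0.02 log units lower from compound 1 to compound 4 (within the scatter) in size. In this assay compound 4 is estimated at 4.55 with an expected range from 4.15 to 4.95.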

Compound 4, partition coefficient: 4.82
Beside the measured number, compound 4's estimate is 0.27 log units below it; low and high end bracket the measured number.
By their numbers in this assay, from the lowest: compounds 1 and 4 (each within the scatter of the next); then compounds 2 and 3 (each within the scatter of the next).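

In this assay, the exchange of methoxy for hydrogen on an aromatic carbon now gives the series its first step in which only one place differs: a number 0.25 log units higher from compound 1 to compound 4 (within the scatter). At this place, on a six-membered aromatic ring of carbon only and meta to a large group, taking away methoxy with its 2 heavy atoms and 1 hydrogen-bond acceptor therefore leaves the read-out within the usual scatter of repeated measurements, and this single pair sets no firm direction for the exchange. No measured property of either group bears on this step, so it stands as an observation without an assigned cause.

Still open, going by these compounds, is how other groups on the same aromatic carbon would read against compound 4, for example an amine, a carboxylic acid or a longer chain joined through oxygen. One pair also cannot show whether methoxy and hydrogen would read as closely at another place on the aromatic ring, or on a structure other than the core of compound 1.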